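Trimming an allyloxy chain on a shared quinoline-free core

The source may hold more compounds than are shown below. What is called first, only, known or untested is meant among the compounds shown, and "the series" means these compounds.

Of the compounds shown here, two have been tested in a functional assay on RKO cells (Homo sapiens) for cytotoxicity, read by MTT assay, with a stated time of 48 h; a lower number here means a stronger inhibitor, a higher number a weaker inhibitor. Compound 1 `CCCCCCOc1ccc2c(Cl)ccnc2c1` gives 2720 nM in this assay. Compound 2 `C=CCOc1ccc2c(NCCCN(C)C)ccnc2c1` gives 3560 nM in this assay, which is the higher of the two numbers, but compound 1 sits within the scatter of it, so no order between the two can be claimed. The next compound, compound 3 `CCOc1ccc2c(NCCCN(C)C)ccnc2c1`, keeps everything in compound 2 except one change: methyl in place of vinyl on a saturated chain carbon bound to an oxygen on an aromatic ring. Read one bond further out, the allyloxy becomes an ethoxy. For the measured compounds named here, no measured pair here shows what such a change does, so there is nothing to anchor a prediction beyond the value of compound 2 itself. The expected step from compound 2 to compound 3 in this assay is small, a 1.3-fold higher number from compound 2 to compound 3 (0.10 log units; within the scatter), and may not exceed the scatter. Compound 3 is therefore estimated at 4500 nM in this assay, within a range from 1800 nM to 12000 nM.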

Compound 3, half-maximal inhibitory concentration in the RKO assay: 5240 nM
Estimate against measurement, compound 3: 1.2-fold (0.07 log units) below; measured number inside the range.
By their numbers in the RKO assay, from the lowest: compounds 1, 2 and 3 (each within the scatter of the next).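

For the compounds shown here, this pair gives the first look at a change in one place: in the RKO assay, replacing the allyloxy with an ethoxy gives a 1.5-fold higher number from compound 2 to compound 3 (0.17 log units; within the scatter) and so removes the double bond outside the aromatic rings without a step beyond the scatter. In a physicochemical assay for solubility (on this read-out lower numbers stand for lower solubility and higher numbers for higher solubility), compound 2 gives > 10000 ug/mL, which is a limit of the assay and not a number. In the physicochemical assay compound 3 gives > 10000 ug/mL, again a limit and not a number.

Going by these compounds alone, no step in solubility can be read between these two compounds, because both values sit at the same limit: the limit of > 10000 ug/mL in the physicochemical assay, at which 2 of the 2 values shown sit. Still open, from the compounds shown here alone, is whether a different group on this oxygen, such as a methyl or a chain ending in an amine, would give a step beyond the scatter in the RKO assay.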